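Swapping a Thienylsulfanyl Arm for a Triazole

The compounds below may be only part of what the source reports. "The series", "measured", "known", "first", "only" and "open" are said of these compounds alone.

Compound 1 `O=C1O[C@@H](Cn2ccnc2)CN1c1ccc(-n2cc(-c3ccccn3)cn2)c(F)c1` gives 350 ug/mL in an ADME assay on L02 cells (Homo sapiens) for cytotoxicity, read by MTT assay, with a stated time of 48 h; a lower number here means a stronger inhibitor, a higher number a weaker inhibitor. Compound 2 `O=C1O[C@@H](CSc2cccs2)CN1c1ccc(-n2cc(-c3ccccn3)cn2)c(F)c1` reports only a limit of the assay, > 400 ug/mL, in this assay. That limit is the limit of > 400 ug/mL in this assay, at which 1 of the 2 values shown sits. Among the measured compounds shown here, the one measured step, an at least 1.1-fold higher number from compound 1 to compound 2 (0.05 log units; that floor lies within the scatter), lies within the scatter. Compound 3 `O=C1O[C@@H](Cn2ccnn2)CN1c1ccc(-n2cc(-c3ccccn3)cn2)c(F)c1` carries 1H-1,2,3-triazol-1-yl in place of (thiophen-2-yl)sulfanyl on a saturated chain carbon bound to a saturated ring carbon. For the measured compounds named here, the group entering, like the one on compound 1, is a five-membered aromatic ring with nitrogen, so no shift beyond the scatter is expected in this assay. The expected step is an at least 1.0-fold lower number from compound 2 to compound 3 (0.02 log units; that floor lies within the scatter). Compound 3 is estimated at 380 ug/mL, with a range from 220 ug/mL to 650 ug/mL.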

Compound 3, half-maximal inhibitory concentration: 49 ug/mL
Beside the measured number, compound 3's estimate is 7.8-fold (0.89 log units) above it; measured number outside the range, below it.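

At the saturated chain carbon bound to a saturated ring carbon, the choice of five-membered aromatic ring clearly matters in this assay: 1H-1,2,3-triazol-1-yl in place of 1H-imidazol-1-yl gives a 7.1-fold lower number from compound 1 to compound 3 (0.85 log units; beyond the scatter), whereas the earlier step lay within the scatter. The same group in place of (thiophen-2-yl)sulfanyl gives an at least 8.1-fold lower number from compound 2 to compound 3 (0.91 log units; beyond the scatter). Compound 2 gives a limit of the assay, not a number: the limit of > 400 ug/mL in this assay, at which 1 of the 3 values shown sits.

Why the two nitrogen rings differ remains open. So does whether 1H-tetrazol-1-yl or a simple amine at this place would track compound 3 or compound 1.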